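A Changed Pyridine Arm on a Shared Core

A few compounds are considered here, and "the series" means these few. Any claim that something is new, unique, unknown or untested is made for them only; others in the source may bear on it.

Measured so far:
compound 1, `O=C(O)c1cc(-c2cnc(C(=O)CCc3ccc(-c4ccccc4)cc3)o2)ccn1`, 50 nM
compound 2, `CN(C)C(=O)c1cnc(C(=O)CCc2ccc(COc3ccccc3)cc2)o1`, 6.7 nM
compound 3, `COC(=O)c1ccc(-c2cnc(C(=O)CCc3ccc(COc4ccccc4)cc3)o2)nc1`, 3.5 nM

All three were tested in an assay for inhibition of Fatty-acid amide hydrolase 1 (Rattus norvegicus); on this read-out higher numbers stand for weaker inhibition and lower numbers for stronger inhibition. Compound 1 gives 50 nM, the highest of the three numbers, so it is the weakest inhibitor of the set. Compound 2 gives 6.7 nM, and compound 3 gives 3.5 nM.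

Compound 4, `NC(=O)c1ccc(-c2cnc(C(=O)CCc3ccc(-c4ccccc4)cc3)o2)nc1`, keeps the core and tail of compound 1 and changes only the arm on the five-membered ring: 5-carbamoylpyridin-2-yl in place of 2-carboxypyridin-4-yl on an aromatic carbon. Going by the values given here, the only measured step at this position is a 1.9-fold lower number from compound 2 to compound 3 (0.28 log units; within the scatter), which lies within the scatter; it involves other groups and compounds with a different tail, so it bears on the present change only loosely. Because compound 3 carries a related pyridine arm and gives 3.5 nM, a somewhat lower number than compound 1 is expected, estimated as a 2.5-fold lower number from compound 1 to compound 4 (0.40 log units; beyond the scatter). Compound 4 is therefore expected to give about 20 nM, with a range from 5 nM to 80 nM.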

Compound 4, inhibition constant: 1.3 nM
Compound 4: the middle estimate sits 15-fold (1.19 log units) above what was measured; measured number below the stated range.
By their numbers in this assay, from the lowest: compound 4; then compounds 3 and 2 (each within the scatter of the next); then compound 1.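

In this assay, replacing 2-carboxypyridin-4-yl with 5-carbamoylpyridin-2-yl on the shared core gives a 38-fold lower number from compound 1 to compound 4 (1.59 log units; beyond the scatter). Going by these compounds alone, the only earlier step at this place, a 1.9-fold lower number from compound 2 to compound 3 (0.28 log units; within the scatter), involved different groups and a different tail and stayed within the scatter, so this is the first evidence here that changing this arm can move the number well beyond the scatter. The two arms match in heavy-atom count and in hydrogen-bond donor and acceptor counts, so those counts do not separate them, and no available evidence explains the large step.

The change alters both the group on the pyridine and how the pyridine is joined to the core, and the compounds shown do not separate these two changes. As far as these compounds go, it also remains open how an arm carrying an amine or a nitrile in place of the carbamoyl group would behave on this core.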